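A 3-(methanesulfonamido)phenyl group replaces 4-methylthiophen-2-yl

A few compounds are considered here, and "the series" means these few. Any claim that something is new, unique, unknown or untested is made for them only; others in the source may bear on it.

In an ADME assay (liver) for metabolic stability, with Liver microsome (Homo sapiens) as the target, using microsomes and NADPH, with a stated time of 30 min, tested at 1 uM (on this read-out higher numbers stand for fast clearance and lower numbers for slow clearance), compound 1 (`COCC#Cc1cc(C(O)(C(F)(F)F)C(F)(F)F)cnc1N1CCN(S(=O)(=O)c2ccc(N)nc2)CC1`) gives 15 mL.min-1.g-1, compound 2 (`Cn1cc(-c2cc(C(O)(C(F)(F)F)C(F)(F)F)cnc2N2CCN(S(=O)(=O)c3ccc(N)nc3)CC2)cn1`) gives 19 mL.min-1.g-1 and compound 3 (`Cc1csc(-c2cc(C(O)(C(F)(F)F)C(F)(F)F)cnc2N2CCN(S(=O)(=O)c3ccc(N)nc3)CC2)c1`) gives 29 mL.min-1.g-1. Compound 3 thus stands within the usual scatter of both other compounds. Compound 4 (`CS(=O)(=O)Nc1cccc(-c2cc(C(O)(C(F)(F)F)C(F)(F)F)cnc2N2CCN(S(=O)(=O)c3ccc(N)nc3)CC2)c1`) carries 3-(methanesulfonamido)phenyl in place of 4-methylthiophen-2-yl on an aromatic carbon, ortho to a large group: 3-(methanesulfonamido)phenyl in place of 4-methylthiophen-2-yl on an aromatic carbon. Among the measured compounds shown here, no measured compound carries this new group, so the closest evidence is the exchange of groups at this place. That evidence comprises a 1.3-fold higher number from compound 1 to compound 2 (0.10 log units; within the scatter), a 1.9-fold higher number from compound 1 to compound 3 (0.29 log units; within the scatter) and a 1.5-fold higher number from compound 2 to compound 3 (0.18 log units; within the scatter). Given these steps, no change beyond the scatter is expected, and the estimated step is a 1.4-fold lower number from compound 3 to compound 4 (0.14 log units; within the scatter). For compound 4 the estimate is 21 mL.min-1.g-1, with an expected range from 10 mL.min-1.g-1 to 42 mL.min-1.g-1.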

Compound 4, intrinsic clearance in microsomes: 40 mL.min-1.g-1
The estimate for compound 4 lay 1.9-fold (0.28 log units) below the measured number; the range from low to high includes it.
By their numbers in this assay, from the lowest: compounds 1, 2, 3 and 4 (each within the scatter of the next, the first and the last beyond it).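

In this assay, among the compounds shown here, the 3-(methanesulfonamido)phenyl group produces the first steps at this position that pass the scatter, with a 2.1-fold higher number from compound 2 to compound 4 (0.32 log units; beyond the scatter) and a 2.7-fold higher number from compound 1 to compound 4 (0.43 log units; beyond the scatter), while a 1.4-fold higher number from compound 3 to compound 4 (0.14 log units; within the scatter) stays within it. An exchange at this aromatic carbon, ortho to a large group, can therefore shift intrinsic clearance beyond the scatter, though only modestly. Nothing measured here accounts for these steps. On these data alone, whether the phenyl ring or the methanesulfonamido group carries the steps stays open. So does how a plain phenyl, an aminomethyl group or a carboxylic acid would read at this place.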